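From ethoxy to propoxy on the shared core

The source may report more compounds than this note shows. Statements on the series, on what has been measured and on what is new or still open speak of the compounds shown alone.

Among the measured compounds shown here, in a functional assay on MCF7 cells (Homo sapiens) for cytotoxicity, read by WST assay, with a stated time of 72 h (a lower number here means a stronger inhibitor, a higher number a weaker inhibitor), compound 2 `CCOc1ccc(C2(c3ccc(O)cc3)C(=O)Nc3c2ccc(F)c3F)cc1` gives 11 nM, the only single number available in this small set. Compound 1 `COc1ccc(C2(c3ccc(O)cc3)C(=O)Nc3c2ccc(F)c3F)cc1` has several entries that do not settle on one number, 2.1 nM; 6.3 nM; > 1000 nM (3 entries). One of these entries is a limit of the assay and not a number.

Compound 3 `CCCOc1ccc(C2(c3ccc(O)cc3)C(=O)Nc3c2ccc(F)c3F)cc1` differs from compound 2 by methyl in place of hydrogen on a saturated chain carbon, two bonds along the chain from an oxygen on an aromatic ring, so that ethoxy becomes propoxy. For the measured compounds named here, no measured step between two compounds is available to guide the expectation in this assay, and the entries of compound 1 the several entries of compound 1 in this assay, 2.1 nM; 6.3 nM; > 1000 nM (3 entries) are too far apart to provide one. The estimated 1.8-fold higher number from compound 2 to compound 3 (0.26 log units; within the scatter) is therefore expected to stay within the usual scatter, leaning only slightly towards a weaker inhibitor. Compound 3 is expected at 20 nM, with an estimated range from 6 nM to 80 nM.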

Compound 3, half-maximal inhibitory concentration: 356 nM
The estimate for compound 3 lay 18-fold (1.25 log units) below the measured number; measured number above the stated range.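

In this assay, a methyl in place of hydrogen on a saturated chain carbon, two bonds along the chain from an oxygen on an aromatic ring, turning ethoxy into propoxy, gives a 32-fold higher number from compound 2 to compound 3 (1.51 log units; beyond the scatter). Among the compounds shown here, this is the first readable step in the set, and it shows that the number at this position can respond strongly to so small a change in the chain. It cannot be placed on a trend from methoxy through ethoxy to propoxy, since compound 1 offers no single number for comparison, and one of its entries is a limit of the assay and not a number: the several entries of compound 1 in this assay, 2.1 nM; 6.3 nM; > 1000 nM (3 entries)

The compounds shown leave open whether a butoxy chain would raise the number further. They also leave open whether a branched isopropoxy group or an amine at the chain end would bring it back down.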